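A few compounds are considered here, and "the series" means these few. Any claim that something is new, unique, unknown or untested is made for them only; others in the source may bear on it.

- Compound 1 `COc1cccc(NC(=O)c2nnn(CC3CCN(C(C)=O)CC3)c2N)c1`: 0.7 mL.min-1.g-1
- Compound 2 `COc1cccc(NC(=O)c2nnn(CC3CCNCC3)c2N)c1`: < 0.5 mL.min-1.g-1

In an ADME assay on microsomes from liver (Mus musculus, strain CD1) for metabolic stability, read by HPLC, using NADPH, with a stated time of 30 min (on this read-out lower numbers stand for slow clearance and higher numbers for fast clearance), compound 2 gives < 0.5 mL.min-1.g-1, which is a limit of the assay and not a number. Compound 3 `COc1cccc(NC(=O)c2nnn(CC3CCN(C(=O)OC(C)(C)C)CC3)c2N)c1` makes one change to compound 2: tert-butoxycarbonyl in place of hydrogen on an amine nitrogen in a ring. For the measured compounds named here, the one measured step that bears on this is an at least 1.4-fold lower number from compound 1 to compound 2 (0.14 log units; that floor lies within the scatter). Its size is known only as a floor, so read in reverse it offers weak support for a rise. A modest rise in this assay is therefore expected, and the estimated step is an at least 4.0-fold higher number from compound 2 to compound 3 (0.60 log units; beyond the scatter). For compound 3 the expected value is 2 mL.min-1.g-1, with an estimated range from 0.6 mL.min-1.g-1 to 7 mL.min-1.g-1.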

Compound 3, intrinsic clearance in microsomes: 10 mL.min-1.g-1
Beside the measured number, compound 3's estimate is 5.0-fold (0.70 log units) below it; measured number above the stated range.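

In this assay, for the compounds shown here, what sits on the amine nitrogen in the ring can matter far more than the earlier compounds showed, with an at least 20-fold higher number from compound 2 to compound 3 (1.30 log units; beyond the scatter). The value of compound 2 is a limit of the assay and not a number, so that step is known only as a floor: the limit of < 0.5 mL.min-1.g-1 in this assay, at which 1 of the 3 values shown sits. Compounds 1 and 3 both carry a carbonyl there, yet tert-butoxy in place of methyl gives a 14-fold higher number from compound 1 to compound 3 (1.15 log units; beyond the scatter), so the carbonyl alone does not set the clearance. Going by these compounds, whether a methoxycarbonyl or a plain methyl group on that nitrogen would stay near compound 1 or approach compound 3 remains open.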